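From piperazin-1-yl to 1H-1,2,3-triazol-1-yl on the shared core

A few compounds are considered here, and "the series" means these few. Any claim that something is new, unique, unknown or untested is made for them only; others in the source may bear on it.

In a physicochemical assay for lipophilicity (on this read-out higher numbers stand for higher lipophilicity and lower numbers for lower lipophilicity), compound 2 (`O=S(=O)(Nc1nccs1)c1ccc2c(c1)OCC[C@@H]2c1ccc(C(F)(F)F)cc1N1CCNCC1`) gives 1.4 as the lower of two numbers, while compound 1 (`O=S(=O)(Nc1nccs1)c1ccc2c(c1)OCC[C@@H]2c1ccc(C(F)(F)F)cc1-c1ccc(F)cc1`) gives 4.5 as the higher. Compound 3 (`O=S(=O)(Nc1nccs1)c1ccc2c(c1)OCC[C@@H]2c1ccc(C(F)(F)F)cc1-n1ccnn1`) has 1H-1,2,3-triazol-1-yl in place of piperazin-1-yl on an aromatic carbon, and the change counts as 1H-1,2,3-triazol-1-yl in place of piperazin-1-yl on an aromatic carbon in full. Going by the values given here, one measured step bears on it at that same place: a number 3.10 log units lower from compound 1 to compound 2 (beyond the scatter) is large. On that single step, a large rise in this assay is expected, though one smaller than that step. The estimate is a number 1.60 log units higher from compound 2 to compound 3 (beyond the scatter) as the expected move. Compound 3 is expected at 3 as the middle, with 2.3 to 3.7 as the estimated range.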

Compound 3, distribution coefficient: 2.3
Compound 3: middle estimate off by 0.70 log units, on the high side; the measured number falls inside the stated range.
By their numbers in this assay, from the lowest: compound 2; then compound 3; then compound 1.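

At this place on the shared core, the 1H-1,2,3-triazol-1-yl group puts compound 3 in the middle in this assay, with a number 0.90 log units higher from compound 2 to compound 3 (beyond the scatter) and a number 2.20 log units lower from compound 1 to compound 3 (beyond the scatter). The new compound therefore stands nearer to compound 2 than to compound 1, so an aromatic ring here does not by itself bring the number up to that of compound 1. Still open, on these data alone, is where a morpholine or a pyridine ring would fall at this same place. Nothing measured here accounts for the size of either step.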